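The source may report more compounds than this note shows. Statements on the series, on what has been measured and on what is new or still open speak of the compounds shown alone.

Measured so far in a toxicity assay on cells (Fibroblast, Homo sapiens) for cytotoxicity; on this read-out higher numbers stand for weaker inhibition and lower numbers for stronger inhibition:

compound 1, `COc1cc(O)c(C(=O)OC/C=C(C)/C=C/C=C(C)/C=C/C2=CCCCC2(C)C)c(O)c1`: 14000 nM
compound 2, `COc1cc(NC(C)=O)cc(C(=O)OC/C=C(C)/C=C/C=C(C)/C=C/C2=CCCCC2(C)C)c1O`: < 10000 nM
compound 3, `COc1cccc(C(=O)OC/C=C(C)/C=C/C=C(C)/C=C/C2=CCCCC2(C)C)c1O`: 27000 nM

Compound 1 gives the lowest of the two plain numbers in this assay; compound 3 sits nearest, and the step of a 1.9-fold higher number from compound 1 to compound 3 (0.29 log units; within the scatter) is within the usual scatter, so the two cannot be ordered. For compound 2 the assay reports only a limit, (the limit of < 10000 nM in this assay, at which 1 of the 3 values shown sits), not a number. The step of an at least 2.7-fold higher number from compound 2 to compound 3 (0.43 log units; beyond the scatter) is at least modest and runs toward weaker inhibition.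

Compound 4, `CC(/C=C/C1=CCCCC1(C)C)=C\C=C\C(C)=C\COC(=O)c1cc(O)c(O)c(O)c1`, is not yet measured. It differs from compound 1 on the carbonyl carbon: a group of 9 heavy atoms (6 carbon, 3 oxygen; one six-membered aromatic ring of carbon only) in place of a group of 10 heavy atoms (7 carbon, 3 oxygen; one six-membered aromatic ring of carbon only), on a carbonyl carbon. Among the compounds with values here, the only measured step that also exchanges the aryl group on that carbonyl carbon is the one from compound 1 to compound 3, and that step stayed within the scatter; the step from compound 2 to compound 3 concerns an acetamido on an aromatic carbon and does not bear directly on a 3,4,5-trihydroxyphenyl. On that basis no step beyond the scatter is expected for compound 4 in this assay, and the expected change no change at the digits printed from compound 1 to compound 4 (within the scatter) is taken as small in either direction. The estimate for compound 4 in this assay is 14000 nM, expected between 6000 nM and 35000 nM.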

Compound 4, half-maximal inhibitory concentration: 35000 nM
For compound 4 the middle estimate is 2.5-fold (0.40 log units) below the measured one; measured number inside the range.
By their numbers in this assay, from the lowest: compounds 1, 3 and 4 (each within the scatter of the next, the first and the last beyond it). At a limit, below all of these: compound 2.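

In this assay an exchange of the aryl group on the carbonyl carbon can move the number beyond the scatter: the step of a 2.5-fold higher number from compound 1 to compound 4 (0.40 log units; beyond the scatter) is modest and runs toward weaker inhibition, whereas the step of a 1.9-fold higher number from compound 1 to compound 3 (0.29 log units; within the scatter) does not leave the scatter. The 3,4,5-trihydroxyphenyl and 2-hydroxy-3-methoxyphenyl groups cannot be ordered, as the step of a 1.3-fold higher number from compound 3 to compound 4 (0.11 log units; within the scatter) is within the scatter, so compound 3 cannot be separated from either compound 1 or compound 4 and only the two ends of this short run differ. Nothing measured here gives a cause for the step between compound 1 and compound 4.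

On these data alone, whether the step follows from the loss of the methoxy group or from the added hydroxy groups stays open, since the aryl groups of compound 1 and compound 4 differ in both. Also open, as far as these compounds go, is whether an aryl group carrying an amine or a carboxylic acid on this carbonyl carbon would stay within the scatter of compound 1 or move beyond it, and in which direction.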